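Swapping tert-butyl for cyano on the benzyl ring

This account rests on a few compounds, and the source may have more. Where it says the series, first, only, none or still open, it means among the compounds named here.

Compound 2 `CC(C)(C)c1ccc(CN2CC=C(CCC(=O)NO)C2=O)cc1` gives 2.1 in a physicochemical assay for lipophilicity (on this read-out lower numbers stand for lower lipophilicity and higher numbers for higher lipophilicity), the highest of the two numbers measured; compound 1 `O=C(CCC1=CCN(Cc2ccc(Br)cc2)C1=O)NO` gives 1.26. Going by the values given here, the one measured step, a number 0.84 log units higher from compound 1 to compound 2 (beyond the scatter), came with tert-butyl in place of bromo. Compound 3 `N#Cc1ccc(CN2CC=C(CCC(=O)NO)C2=O)cc1` differs from compound 2 by cyano in place of tert-butyl on an aromatic carbon. Among the compounds with values here, no measured step shows cyano directly, but the step from compound 1 to compound 2 shows how much tert-butyl raised this assay over bromo, so removing it is expected to take the number back down, by an estimated a number 1.70 log units lower from compound 2 to compound 3 (beyond the scatter). Compound 3 is therefore expected to give 0.4, within -0.2 to 1.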

Compound 3, distribution coefficient: 0.197
For compound 3 the middle estimate is 0.20 log units above the measured one; low and high end bracket the measured number.
By their numbers in this assay, from the lowest: compound 3; then compound 1; then compound 2.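

In this assay, cyano gives the lowest number of the three groups at this aromatic carbon, with a number 1.90 log units lower from compound 2 to compound 3 (beyond the scatter) and a number 1.06 log units lower from compound 1 to compound 3 (beyond the scatter). Bromo therefore falls between cyano and tert-butyl, and changing only this one group moves the read-out further than the earlier step alone showed. Nothing available here explains the size of these steps.

The compounds shown leave open where an amine or a carboxylic acid on this same carbon would fall, including whether either would give a number lower than compound 3 does.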